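A few compounds are considered here, and "the series" means these few. Any claim that something is new, unique, unknown or untested is made for them only; others in the source may bear on it.

In a functional assay on HCT-116 cells (Homo sapiens) for antiproliferative activity, read by MTT assay, with a stated time of 72 h (on this read-out higher numbers stand for weaker inhibition and lower numbers for stronger inhibition), three compounds have been measured. Compound 1 `Cc1ccc(S(=O)(=O)NCc2cn(C[C@H](O)[C@H]3OC(=O)C(OCc4ccccc4)=C3OCc3ccccc3)nn2)cc1` gives 13100 nM. Compound 2 `Cc1ccc(-c2cn(C[C@H](O)[C@H]3OC(=O)C(OCc4ccccc4)=C3OCc3ccccc3)nn2)cc1` reaches only a limit of the assay, > 100000 nM. Compound 3 `O=C1O[C@H]([C@@H](O)Cn2cc(CCCCl)nn2)C(OCc2ccccc2)=C1OCc1ccccc1` gives 36100 nM.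

Among the two numbers that are not limits, compound 3 holds the higher one; the gap to its nearest neighbour is a 2.8-fold higher number from compound 1 to compound 3 (0.44 log units; beyond the scatter). The step now followed leads from compound 3 to compound 4 `O=C1O[C@H]([C@@H](O)Cn2ccnn2)C(OCc2ccccc2)=C1OCc1ccccc1`, and the change is hydrogen in place of 3-chloropropyl on an aromatic carbon.

Within the data shown here, two measured steps touch the same aromatic carbon. One is an at least 2.7-fold lower number from compound 2 to compound 3 (0.44 log units; beyond the scatter), and the other is a 2.8-fold higher number from compound 1 to compound 3 (0.44 log units; beyond the scatter); together they show that the number at this position moves by modest amounts when the group on that carbon is exchanged, with the 4-methylphenyl giving the weakest result and the (((4-methylphenyl)sulfonyl)amino)methyl the strongest. Neither step removes the group altogether, so the direction for a bare hydrogen is not settled by them. The writer expects a modest rise in the number, a 1.5-fold higher number from compound 3 to compound 4 (0.18 log units; within the scatter), with a real chance that only a limit is returned. For compound 4 the estimate is 55000 nM, within a range from 15000 nM to 150000 nM.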

Compound 4, half-maximal inhibitory concentration: > 100000 nM
Compound 4 ended at the assay's limit (the forecaster's own chance of this, stated with the estimate: 30%); middle value at least 1.8-fold (0.25 log units) from the limit.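

In this assay, among these compounds, hydrogen in place of 3-chloropropyl on the aromatic carbon of the five-membered ring gives an at least 2.7-fold higher number from compound 3 to compound 4 (0.44 log units; beyond the scatter), which is the first view of this position with no group on it. Hydrogen in place of (((4-methylphenyl)sulfonyl)amino)methyl gives an at least 7.6-fold higher number from compound 1 to compound 4 (0.88 log units; beyond the scatter), so among the compounds shown, a readable number appears only with a group on this carbon. Compound 2 goes against any simple rule. Its 4-methylphenyl group brings no readable number either. The step between compound 2 and compound 4 cannot be read because each of the two compounds stands at a limit of the assay, not at a number: the limit of > 100000 nM in this assay, at which 2 of the 4 values shown sit.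

The compounds shown leave open which part of the 3-chloropropyl group or of the (((4-methylphenyl)sulfonyl)amino)methyl group carries the difference from hydrogen, since no pair here separates chain length from the chlorine or the sulfonyl unit. Going by these compounds, it also remains open whether a longer chain, or an amine or a carboxylic acid at the end of a chain on this aromatic carbon, would give a lower number than either of these groups.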